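The compounds below may be only part of what the source reports. "The series", "measured", "known", "first", "only" and "open" are said of these compounds alone.

Compound 1 `CCCCCCN(Cc1ccc(C(=O)NO)cc1)c1ncc(-c2ccc(C)cc2)s1` gives 5270 nM in a functional assay on PC-3 cells (Homo sapiens) for antiproliferative activity, read by MTT assay, with a stated time of 48 h; a lower number here means a stronger inhibitor of growth, a higher number a weaker inhibitor of growth.
Compound 2 `Cc1ccc(-c2cnc(N(Cc3ccc(C(=O)NO)cc3)CC(C)C)s2)cc1` gives 9340 nM in this assay.
Compound 3 `Cc1ccc(-c2cnc(N(CCCCOc3ccccc3)Cc3ccc(C(=O)NO)cc3)s2)cc1` gives 10300 nM in this assay.

Compound 3 is not set apart from the other two: a 2.0-fold higher number from compound 1 to compound 3 (0.29 log units; within the scatter) and a 1.1-fold higher number from compound 2 to compound 3 (0.04 log units; within the scatter) both stay within the scatter, so the three numbers cannot be told apart. Compound 4 `CCN(Cc1ccc(C(=O)NO)cc1)c1ncc(-c2ccc(C)cc2)s1` differs from compound 3 by hydrogen in place of 2-phenoxyethyl on a saturated chain carbon, two bonds along the chain from a nitrogen on an aromatic ring. The shown steps that change the same chain on the nitrogen, a 1.8-fold higher number from compound 1 to compound 2 (0.25 log units; within the scatter) and a 1.1-fold higher number from compound 2 to compound 3 (0.04 log units; within the scatter), were both small, and a 2.0-fold higher number from compound 1 to compound 3 (0.29 log units; within the scatter) was small too, so trimming this chain is expected to leave this assay much as it is. For compound 4 the expected step is a 1.3-fold lower number from compound 3 to compound 4 (0.11 log units; within the scatter), with no change beyond the scatter. Compound 4 is therefore estimated at 8000 nM, within 3000 nM to 25000 nM.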

Compound 4, concentration for 50% growth inhibition: 10300 nM
Compound 4: middle estimate off by 1.3-fold (0.11 log units), on the low side; low and high end bracket the measured number.
By their numbers in this assay, from the lowest: compounds 1, 2, 3 and 4 (each within the scatter of the next).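

Removing 2-phenoxyethyl leaves the number where it stood (no change at the digits printed from compound 3 to compound 4 (within the scatter)), so in this assay the phenoxy end of the chain on this nitrogen is not needed to keep this level of growth inhibition. The ethyl chain, the shortest shown, also stays within the scatter of the others (a 1.1-fold higher number from compound 2 to compound 4 (0.04 log units; within the scatter); a 2.0-fold higher number from compound 1 to compound 4 (0.29 log units; within the scatter)), so across these four compounds neither chain length nor branching nor a phenoxy end gives a readable difference. Nothing measured here explains this flat result. Still open, from the compounds shown here alone, is whether an amine or a carboxylic acid at the end of this chain would move the number.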